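This account rests on a few compounds, and the source may have more. Where it says the series, first, only, none or still open, it means among the compounds named here.

Working notes on the series. The shared core is carried by compound 1 `COc1nc(-c2cccc(Cl)c2)ccc1[C@@H](c1ccccc1)[C@@](O)(CCN(C)C)c1cccc2ccccc12`, compound 2 `COc1ncc(-c2ccccc2)cc1[C@@H](c1ccccc1)[C@@](O)(CCN(C)C)c1cccc2ccccc12`, compound 3 `COc1nc(-c2cnsc2)ccc1[C@@H](c1ccccc1)[C@@](O)(CCN(C)C)c1cccc2ccccc12` and compound 4 `COc1nc(-c2ccsc2)ccc1[C@@H](c1ccccc1)[C@@](O)(CCN(C)C)c1cccc2ccccc12`. In a toxicity assay on HeLa cells (Homo sapiens) for cytotoxicity (a lower number here means that less compound is tolerated, a higher number that more compound is tolerated), compound 2 gives 30.4 ug/mL, and compound 3 gives 28.8 ug/mL. For compound 1 the entry in this assay reads "nd" (no result reported), that is, no result has been reported. Compound 3 thus holds the lowest of the two numbers available, but its nearest neighbour, compound 2, sits within the usual scatter of it, so no order between the two can be read from these data.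

Compound 4 differs from compound 3 in one place: thiophen-3-yl in place of 1,2-thiazol-4-yl on an aromatic carbon. The change exchanges one five-membered aromatic ring with 2 hetero atoms for one five-membered aromatic ring with 1 hetero atom. Among the measured compounds shown here, no measured pair in this set isolates such a change, and the two measured compounds that do carry different aromatic groups at that position, compound 2 and compound 3, lie within the scatter of each other. Expected is therefore a 1.0-fold lower number from compound 3 to compound 4 (0.01 log units; within the scatter), nothing beyond the scatter in either direction. For compound 4 the expected value in this assay is 28 ug/mL, with a range of 14 ug/mL to 56 ug/mL.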

Compound 4, half-maximal cytotoxic concentration: > 64 ug/mL
Compound 4: no number, only a limit; the forecaster's own chance of this, stated with the estimate: 5%; middle value at least 2.2-fold (0.35 log units) from the limit.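

Among the compounds shown here, at the aromatic carbon next to the ring nitrogen, thiophen-3-yl in place of 1,2-thiazol-4-yl gives the first step that lies beyond the scatter in this assay, namely an at least 2.2-fold higher number from compound 3 to compound 4 (0.34 log units; beyond the scatter) in this read-out. For compound 4 the entry > 64 ug/mL is a limit and not a number. This position therefore responds to the exchange of one five-membered aromatic ring with 2 hetero atoms for one with 1 hetero atom, and the size of the step is bounded on one side only: the limit of > 64 ug/mL in this assay, at which 1 of the 4 values shown sits.

Open, from the compounds shown here alone, is how an amine, a carboxylic acid or a longer chain at this position would read in this assay. Going by these compounds, the exchange appears in this single pair, so whether it gives a similar step elsewhere on the shared core also stays open.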